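The source may report more compounds than this note shows. Statements on the series, on what has been measured and on what is new or still open speak of the compounds shown alone.

Compound 1 `O=C(Nc1ccc(Cl)cc1)N1CCC[C@H]1c1nc(-c2ccccc2Cl)no1`, tested in an ADME assay on MCF-10A cells (Homo sapiens) for inhibition, with a stated time of 48 h (a higher number here means a weaker inhibitor, a lower number a stronger inhibitor), gives only a limit, > 50000 nM.
Compound 2 `O=C(Nc1ccc(Cl)cc1)N1CCC[C@H]1c1nc(-c2ccc(Br)cc2)no1` gives in this assay only a limit, > 50000 nM.
Compound 3 `O=C(Nc1ccc(Cl)cc1)N1CCC[C@H]1c1nc(-c2ccc(I)cc2)no1` gives in this assay only a limit, > 50000 nM.

Compound 1 therefore has no measured number in this assay, only a limit, and the same holds for the two other measured compounds. The steps among them cannot be read: from compound 1 to compound 2 a step that the two limits leave unreadable from compound 1 to compound 2, from compound 1 to compound 3 a step that the two limits leave unreadable from compound 1 to compound 3, and from compound 2 to compound 3 a step that the two limits leave unreadable from compound 2 to compound 3. Within the data shown here, the only evidence on record is the limit of > 50000 nM in this assay, at which 3 of the 3 values shown sit.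

Compound 4 `N#Cc1ccc(-c2noc([C@@H]3CCCN3C(=O)Nc3ccc(Cl)cc3)n2)cc1` differs from compound 1 in one place: 4-cyanophenyl in place of 2-chlorophenyl on an aromatic carbon. Among the measured compounds shown here, no measured step concerns a 4-cyanophenyl group, and none of the three measured steps has a readable size, so they give no direction for this change. Because all three measured compounds sit at the limit of > 50000 nM in this assay, at which 3 of the 3 values shown sit, compound 4 is expected to behave the same way, with a step from compound 1 that is estimated as a number no higher from compound 1 to compound 4 (the limit leaves the size open). The value for compound 4 in this assay is estimated at 50000 nM, within a range from 20000 nM to 120000 nM, and most likely it too will be reported only as a limit.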

Compound 4, half-maximal inhibitory concentration: > 50000 nM
Compound 4 was reported as a limit; the forecaster's own chance of this, stated with the estimate: 85%; the middle value lies on the limit itself.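

Among these compounds, compound 4, like compound 1, compound 2 and compound 3, gives only a limit, so no step between compound 4 and these three can be read: the limit of > 50000 nM in this assay, at which 4 of the 4 values shown sit. The compounds shown leave open how strongly any of them inhibits in this assay and whether changing the group on the shared core alters that at all.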